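Sulfonanilide pair series: methyl removal at inhibition limit

The source may report more compounds than this note shows. Statements on the series, on what has been measured and on what is new or still open speak of the compounds shown alone.

Measured compounds:
Compound 1, `Cc1ccc(S(=O)(=O)Nc2ccc(NS(=O)(=O)c3ccc(F)cc3)cc2)cc1`: in an assay for inhibition of liver carboxylesterase 1 (Homo sapiens), read by spectrophotometry (on this read-out higher numbers stand for weaker inhibition and lower numbers for stronger inhibition), compound 1 reaches only a limit of the assay, > 100000 nM.
Compound 2, `Cc1ccc(S(=O)(=O)Nc2ccc(NS(=O)(=O)c3ccc(F)c(F)c3)cc2)cc1`: in this assay compound 2 likewise reaches only a limit, > 100000 nM.
Compound 3, `Cc1ccc(S(=O)(=O)Nc2ccc(NS(=O)(=O)c3cc(F)ccc3F)cc2)cc1`: in this assay compound 3 likewise reaches only a limit, > 100000 nM.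

Compound 2 stands where the whole set stands: at a limit, with no number, and the two further values shown are limits as well. Compound 4, `O=S(=O)(Nc1ccc(NS(=O)(=O)c2ccc(F)c(F)c2)cc1)c1ccccc1`, differs from compound 2 by hydrogen in place of methyl on an aromatic carbon. The measured steps that bear on it all run between limits and are therefore not readable in size: a step that the two limits leave unreadable from compound 1 to compound 2, a step that the two limits leave unreadable from compound 1 to compound 3, and a step that the two limits leave unreadable from compound 2 to compound 3. All three values sit at the limit of > 100000 nM in this assay, at which 3 of the 3 values shown sit, so no direction can be read for any change in this set. Nothing here indicates that removing the methyl would pull the value down into the readable range; the expected step is a step that the limit leaves unreadable from compound 2 to compound 4. For compound 4 in this assay the estimate is 150000 nM, with a range from 50000 nM to 500000 nM, most likely reported again as a limit.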

Compound 4, inhibition constant: > 100000 nM
Compound 4: no number, only a limit; the forecaster's own chance of this, stated with the estimate: 85%; the middle value does not contradict the limit.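

Within the data shown here, compound 2 and compound 4 give no new readable step, as each reaches only a limit in this assay. The compounds shown leave open whether any change to the shared core would bring a value into the readable range.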